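The compounds below may be only part of what the source reports. "The series", "measured", "known", "first", "only" and "open" are said of these compounds alone.

Compound 1 `O=C(O)CC1COc2cc(OCc3nnc(-c4ccccc4)o3)ccc21` gives 1.54% in a functional assay on CHO cells for agonist activity at Free fatty acid receptor 1 (Homo sapiens), read by FLIPR and calcium flux, tested at 100 nM; on this read-out higher numbers stand for a stronger effect at the one concentration tested and lower numbers for a weaker effect. Compound 2 `O=C(O)CC1COc2cc(OCc3nnc(-c4ccccc4)s3)ccc21` gives 3.36% in this assay. Compound 3 `Cc1ccccc1-c1nc(C)c(COc2ccc3c(c2)OCC3CC(=O)O)s1` gives 10.7% in this assay.

All three compounds share one core and differ only in the group carried on the ether. Compound 3 has the highest of the three numbers, but its distance to compound 2 and its distance to compound 1 both lie within the scatter of this kind of measurement, so the three cannot be told apart on these numbers alone. Within the data shown here, no pair among them differs in a single place, so no step is counted between them.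

Compound 4 `Cc1nc(-c2ccc(C(F)(F)F)cc2)sc1COc1ccc2c(c1)OCC2CC(=O)O` has not yet been measured in this assay. It differs from compound 3 in one place: 4-(trifluoromethyl)phenyl in place of 2-methylphenyl on an aromatic carbon. Among the measured compounds shown here, nothing among the measured compounds shows what this exchange does on the shared core. Compound 4 is therefore expected to land near compound 3, with the step of a number 1.3 percentage points higher from compound 3 to compound 4 (within the scatter) expected to stay within the scatter rather than beyond it. For compound 4 the estimate is 12%, spanning from 3% to 30%.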

Compound 4, a percentage reported as activity, at one concentration (the size of the read-out at that concentration, not a potency): 50.4%
The estimate for compound 4 lay 38.4 percentage points below the measured number, outside the stated range (above it).
By their numbers in this assay, from the lowest: compounds 1, 2 and 3 (each within the scatter of the next); then compound 4.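

In this assay, putting 4-(trifluoromethyl)phenyl in place of 2-methylphenyl, on the aromatic carbon next to the ring nitrogen and next to the ring sulfur, leads to a number 39.7 percentage points higher from compound 3 to compound 4 (beyond the scatter). This shows that the group at this place can move the read-out at the one concentration tested, which compounds 1, 2 and 3 could not show, as they all lie within the scatter of one another. Nothing in the data shown accounts for this step.

The exchange removes the 2-methyl group and brings in the 4-trifluoromethyl group together, and the compounds shown leave open which of the two matters. On these data alone, how a plain phenyl, a 4-methylphenyl or a 4-chlorophenyl would read at this place also remains open.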